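Low toxicity so far, and a new amide group

A few compounds are considered here, and "the series" means these few. Any claim that something is new, unique, unknown or untested is made for them only; others in the source may bear on it.

Measured in an ADME assay on CEM-SS cells (Homo sapiens) for cytotoxicity, read by XTT assay; on this read-out lower numbers stand for higher toxicity in this test and higher numbers for lower toxicity in this test:
- Compound 1 `CN(O)C(=O)c1cc2ccn(Cc3ccc(F)cc3F)c2cn1`: 200000 nM
- Compound 2 `CN(O)C(=O)c1cc2c(CN3CCC(O)C3)cn(Cc3ccc(F)cc3)c2cn1`: > 100000 nM
- Compound 3 `COCCOCc1cn(Cc2ccc(F)cc2)c2cnc(C(=O)N(C)O)cc12`: > 100000 nM

Compound 2 stands at > 100000 nM, which is a limit of the assay. Compound 3 has no exact number either, and its > 100000 nM is also a limit. This is the ceiling shown in the limit of > 100000 nM in this assay, at which 2 of the 3 values shown sit.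

Compound 4 `CN(O)C(=O)c1cc2c(C(=O)N3CCC[C@@H]3CO)cn(Cc3ccc(F)cc3)c2cn1` carries (2-(hydroxymethyl)pyrrolidin-1-yl)carbonyl in place of (2-methoxyethoxy)methyl on an aromatic carbon. The closest measured change is a step that the two limits leave unreadable from compound 2 to compound 3, so it offers no size to carry over. Only compound 1 gives an exact number, 200000 nM, and it points to low toxicity, so low toxicity is expected to persist.

In this assay the expected change is a number no higher from compound 3 to compound 4 (the limit leaves the size open), with no step beyond the usual scatter expected. Compound 4 is estimated at 100000 nM, within an expected range of 30000 nM to 200000 nM.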

Compound 4, half-maximal cytotoxic concentration: > 32000 nM
Compound 4 gave a limit, no number; the forecaster's own chance of this, stated with the estimate: 65%; the middle value does not contradict the limit.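

The steps among compound 2, compound 3 and compound 4 cannot be read, since all three values are limits. Still open, on these data alone, is whether (2-(hydroxymethyl)pyrrolidin-1-yl)carbonyl changes toxicity at all compared with the other two groups.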